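The source may report more compounds than this note shows. Statements on the series, on what has been measured and on what is new or still open speak of the compounds shown alone.

Measured so far:
Compound 1, `C/C(=C\c1cc(-c2ccccc2)co1)C(N)=O`. In a functional assay on BGC-823 cells (Homo sapiens) for cytotoxicity, read by CCK-8 assay, with a stated time of 24 h (on this read-out higher numbers stand for weaker inhibition and lower numbers for stronger inhibition), compound 1 gives > 50000 nM, which is a limit of the assay and not a number.
Compound 2, `C/C(=C\c1cc(-c2ccc(C)cc2)co1)C(N)=O`. In this assay compound 2 gives > 50000 nM, also a limit.
Compound 3, `C/C(=C\c1cc(-c2cccnc2)co1)C(N)=O`. In this assay compound 3 gives > 50000 nM, also a limit.

Compound 1 and compound 2 differ by one change, (methyl in place of hydrogen on an aromatic carbon). The step that the two limits leave unreadable from compound 1 to compound 2, since both values sit at the limit of > 50000 nM in this assay, at which 3 of the 3 values shown sit. Compound 3 carries a different core; the difference between the cores of compound 1 and compound 3 is not broken down here.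

Compound 4, `C/C(=C\c1cc(-c2ccc(C)nc2)co1)C(N)=O`, has not yet been measured. It differs from compound 3 by methyl in place of hydrogen on an aromatic carbon. This is the same kind of change as that from compound 1 to compound 2, but its place is not the same: in compound 2 the methyl enters on a six-membered aromatic ring of carbon only, para to a large group, while in compound 4 it enters on a six-membered aromatic ring with 1 nitrogen, next to the ring nitrogen, para to a large group.

In this assay compound 4 is expected to show the step that the limit leaves unreadable from compound 3 to compound 4, an expectation that rests on (the limit of > 50000 nM in this assay, at which 3 of the 3 values shown sit), where every measured value sits. Compound 4 is therefore estimated at 60000 nM, with a likely range from 20000 nM to 150000 nM.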

Compound 4, half-maximal inhibitory concentration: > 50000 nM
Compound 4 gave a limit, no number (the forecaster's own chance of this, stated with the estimate: 85%); the middle value is on the limit's open side.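

In this assay compound 4 gives > 50000 nM as a limit and not a number. The step from compound 3 to compound 4 therefore cannot be read, since both compounds sit at a limit: the limit of > 50000 nM in this assay, at which 4 of the 4 values shown sit.
The compounds shown leave open whether any of them has a readable value in this assay and how much the added methyl changes it.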